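A few compounds are considered here, and "the series" means these few. Any claim that something is new, unique, unknown or untested is made for them only; others in the source may bear on it.

Compounds measured so far:

Compound 1, `COc1cc(-c2cc(/C=C/C(=O)c3ccc(N)cc3)[nH]n2)cc(OC)c1OC`: 320 nM
Compound 2, `COc1ccc(C(=O)/C=C/c2cc(-c3cc(OC)c(OC)c(OC)c3)n[nH]2)cc1OC`: 270 nM
Compound 3, `COc1ccc(C(=O)/C=C/c2cc(-c3cc(OC)c(OC)c(OC)c3)n[nH]2)cc1`: 340 nM

All three were tested in a functional assay on SR cells (Homo sapiens) for inhibition, read by sulforhodamine B assay, with a stated time of 48 h (a higher number here means a weaker inhibitor of growth, a lower number a stronger inhibitor of growth), and their numbers sit close together. The step of a 1.2-fold lower number from compound 1 to compound 2 (0.07 log units; within the scatter), the step of a 1.1-fold higher number from compound 1 to compound 3 (0.03 log units; within the scatter) and the step of a 1.3-fold higher number from compound 2 to compound 3 (0.10 log units; within the scatter) all stay within the scatter of repeated measurement, so none of the three can be called stronger or weaker than the others on this evidence.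

Compound 4, `COc1ccc(-c2cc(/C=C/C(=O)c3ccc(N)cc3)[nH]n2)cc1OC`, has not yet been tested. It differs from compound 1 by hydrogen in place of methoxy on an aromatic carbon. The same kind of change is already seen between two measured compounds: compound 3 differs from compound 2 by hydrogen in place of methoxy on an aromatic carbon, and that step came out as a 1.3-fold higher number from compound 2 to compound 3 (0.10 log units; within the scatter). The two pairs do not share a core; the cores differ by 4-aminophenyl in place of 3,4-dimethoxyphenyl on a carbonyl carbon. The surroundings of the changed position are also not identical: in compound 1 the position is described as ortho to a methoxy group, meta to a large group and meta to a methoxy group, whereas in compound 2 it is described as ortho to a methoxy group and meta to a large group only. So the change is the same kind of change, not the same change.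

For compound 4 the expected step from compound 1 is a 1.3-fold higher number from compound 1 to compound 4 (0.10 log units; within the scatter), and this expectation rests on the earlier step of a 1.3-fold higher number from compound 2 to compound 3 (0.10 log units; within the scatter), which was small. Compound 4 is therefore estimated at 400 nM in this assay, with an expected range from 200 nM to 800 nM.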

Compound 4, concentration for 50% growth inhibition: 580 nM
The estimate for compound 4 lay 1.5-fold (0.16 log units) below the measured number, and the stated range covers the measured number.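

In this assay, putting hydrogen in place of methoxy on the core of compound 1 gives a 1.8-fold higher number from compound 1 to compound 4 (0.26 log units; within the scatter), so on this evidence compound 4 cannot be called weaker or stronger than compound 1. Set beside the earlier case of this change, on a core that carries 3,4-dimethoxyphenyl in place of 4-aminophenyl on the carbonyl carbon, the two steps cannot be told apart: the same change on two cores in this assay, a 1.3-fold higher number (0.10 log units; within the scatter) from compound 2 to compound 3 and a 1.8-fold higher number (0.26 log units; within the scatter) from compound 1 to compound 4, 1.4-fold (0.16 log units) apart, within the scatter of two such steps This shows that the change gave no step beyond the scatter on either of these two cores, and that a small step seen on one core was a fair guide to the other, but two pairs cannot show that the change would behave the same way on any further core, nor can two steps this small reveal a real but modest difference between cores.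

The compounds shown carry only methoxy or hydrogen at the changed place, so they leave open what a hydroxyl group, a fluorine atom or a longer chain such as ethoxy would do there. They also leave open whether the change would stay this small with a carboxylic acid in place of the amine on the 4-aminophenyl group.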